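A few compounds are considered here, and "the series" means these few. Any claim that something is new, unique, unknown or untested is made for them only; others in the source may bear on it.

The measured compounds and their readings:

Compound 1, `OC[C@H]1O[C@@H](n2cnc3c(NCc4ccccc4)nccc32)C[C@@H]1O`: 15%
Compound 2, `CCCCCCNc1[nH]ccc2ncnc1-2`: 53%
Compound 3, `CSc1nccc2c1ncn2C1O[C@H](CO)[C@@H](O)[C@H]1O`: 24%

In a functional assay (Homo sapiens) for inhibition of Nucleic Acid, tested at 100 uM (a higher number here means more inhibition at the concentration tested (going by the name of the read-out), a lower number less inhibition), compound 3 stands second highest of the three numbers. Its nearest neighbour is compound 1, whose reading lies lower but within the usual scatter of repeated measurements, so the two cannot be told apart. Its furthest neighbour is compound 2, whose reading lies higher by a margin beyond the scatter; compound 2, however, carries a core without the sugar found in compound 1 and compound 3, so the pair says little about a single substituent.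

Compound 4, `OCCNc1nccc2c1ncn2C1O[C@H](CO)[C@@H](O)[C@H]1O`, has not yet been measured. It differs from compound 3 in one place: (2-hydroxyethyl)amino in place of methylsulfanyl on an aromatic carbon. For the measured compounds named here, no change of this kind has been measured here, so the only guide is that compound 1, which also bears an amino group on the shared core, gives 15% in this assay, close to compound 3.

Compound 4 is therefore expected to land near compound 3, with a step of a number 2 percentage points lower from compound 3 to compound 4 (within the scatter) that is estimated to stay within the scatter. The estimate for compound 4 in this assay is 22%, with a range from 5% to 45%.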

Compound 4, a percentage reported as inhibition, at one concentration (the size of the read-out at that concentration, not a potency): 0%
Estimate against measurement, compound 4: 22 percentage points above; the measured number lies below the stated range.
By their numbers in this assay, from the lowest: compound 4; then compounds 1 and 3 (each within the scatter of the next); then compound 2.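

In this assay, for the compounds shown here, putting (2-hydroxyethyl)amino in place of methylsulfanyl on the aromatic carbon next to the ring nitrogen gives a step of a number 24 percentage points lower from compound 3 to compound 4 (beyond the scatter), the first step here to isolate a single group on the shared core. With the core and the sugar held fixed, this shows that the reading is sensitive to the group at this position, and that this exchange, which brings 4 heavy atoms and 2 hydrogen-bond donors in place of 2 heavy atoms and 0 donors, goes with a loss of inhibition at the concentration tested. This single step cannot separate the swap of sulfur for nitrogen from the added chain or its terminal hydroxyl, and nothing measured here explains the drop.

On these data alone, it remains open whether a plain amino group, a methylamino group or an ethylsulfanyl group at this carbon would stay closer to compound 3 or fall with compound 4. As far as these compounds go, it is also open whether the same exchange would have a step of similar size on a core without the sugar.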